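A few compounds are considered here, and "the series" means these few. Any claim that something is new, unique, unknown or untested is made for them only; others in the source may bear on it.

Compound 1 `O=C(Nc1nc2ccc(Oc3ccc(F)c(NC(=O)C4(c5cccc(C(F)(F)F)c5)CC4)c3)cc2s1)C1CC1`: > 50000 nM
Compound 2 `CCOC(=O)c1cccc(NC(=O)Nc2cc(Oc3ccc4nc(NC(=O)C5CC5)sc4c3)ccc2F)c1`: > 50000 nM
Compound 3 `O=C(Nc1nc2ccc(Oc3ccc(F)c(NS(=O)(=O)c4cccc(C(F)(F)F)c4)c3)cc2s1)C1CC1`: "not determined" (no result reported)

These compounds share a core and were tested in an ADME assay on HT-29 cells (Homo sapiens) for cytotoxicity, read by luminescence and CellTiter-Glo, with a stated time of 12 h; a higher number here means that more compound is tolerated, a lower number that less compound is tolerated. In this assay compound 1 gives > 50000 nM, which is a limit of the assay rather than a measured number. Compound 2 likewise gives > 50000 nM in this assay, again a limit and not a number. So compound 2 stands where compound 1 does, at the limit of > 50000 nM in this assay, at which 2 of the 3 values shown sit. Compound 3 adds nothing here, as its entry in this assay reads "not determined" (no result reported).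

Compound 4 `CC(=O)c1cccc(NC(=O)Nc2cc(Oc3ccc4nc(NC(=O)C5CC5)sc4c3)ccc2F)c1` differs from compound 2 in one place: methyl in place of ethoxy on a carbonyl carbon. Within the data shown here, no pair of measured compounds shows what such a change does in this assay. With both measured values sitting at the same limit, no step beyond the usual scatter is expected from compound 2 to compound 4, and compound 4 is expected to remain at or above that limit as well. The estimated step that the limit leaves unreadable from compound 2 to compound 4 reflects this expectation. For compound 4 the estimate is 60000 nM, with a range from 20000 nM to 200000 nM.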

Compound 4, half-maximal cytotoxic concentration: > 50000 nM
Compound 4: no number, only a limit; the forecaster's own chance of this, stated with the estimate: 80%; the middle value is on the limit's open side.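

Among these compounds, no step from compound 2 to compound 4 can be read in this assay, since both compounds give only a limit and not a number: the limit of > 50000 nM in this assay, at which 3 of the 4 values shown sit.

The compounds shown leave open at what concentration compound 1, compound 2 or compound 4 would start to harm these cells.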